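Swapping Iodine for Bromine on a Cysteine-Derived Thiocarbamate

A few compounds are considered here, and "the series" means these few. Any claim that something is new, unique, unknown or untested is made for them only; others in the source may bear on it.

Compound 1 `CC(=O)N[C@@H](CSC(=O)Nc1ccc(I)cc1)C(=O)O` was tested in a functional assay on OVCAR-3 cells (Homo sapiens) for cytotoxicity, read by MTT assay, with a stated time of 6 days; on this read-out lower numbers stand for stronger inhibition and higher numbers for weaker inhibition. In this assay compound 1 reaches only the limit of > 200000 nM. Compound 2 `COc1ccccc1CNC(=O)SC[C@H](NC(C)=O)C(=O)O` likewise gives only the limit > 200000 nM in this assay. Compound 3 `COc1ccccc1NC(=O)SC[C@H](NC(C)=O)C(=O)O` also stops at the limit of > 200000 nM. Across these three compounds (the limit of > 200000 nM in this assay, at which 3 of the 3 values shown sit), so none shows measurable cytotoxicity on these cells. Compound 4 `CC(=O)N[C@@H](CSC(=O)Nc1ccc(Br)cc1)C(=O)O` has not yet been measured. It differs from compound 1 by bromo in place of iodo on an aromatic carbon. Compound 1 sits at the limit > 200000 nM, so a step beyond the scatter is not expected from bromo in place of iodo. Compound 4 is therefore expected to give about 300000 nM, within 100000 nM to 1000000 nM, most likely again only as a limit. The expected step is a step that the limit leaves unreadable from compound 1 to compound 4.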

Compound 4, half-maximal inhibitory concentration: > 200000 nM
Compound 4 gave a limit, no number (the forecaster's own chance of this, stated with the estimate: 90%); the middle value does not contradict the limit.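

Compound 1 and compound 4 both end at a limit, so bromo in place of iodo gives no readable step: the limit of > 200000 nM in this assay, at which 4 of the 4 values shown sit. The compounds shown leave open which change to the shared core, if any, would give a measurable value.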